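The source may report more compounds than this note shows. Statements on the series, on what has been measured and on what is new or still open speak of the compounds shown alone.

Measured compounds:
Compound 1 `Cc1nc2c3ccccc3ccc2c2nc3c(ccc4ccccc43)c(-c3cccnc3)c12` gives 34200 nM in a functional assay on HCT-116 cells (Homo sapiens) for cytotoxicity, read by MTT assay, with a stated time of 48 h; a higher number here means a weaker inhibitor, a lower number a stronger inhibitor.
Compound 2 `Cc1ccc(-c2c3ccc4ccccc4c3nc3c2c(C)nc2c4ccccc4ccc32)cc1` gives 67000 nM in this assay.

Compound 2 has the higher of the two numbers, but only by the step of a 2.0-fold higher number from compound 1 to compound 2 (0.29 log units; within the scatter), which stays within the scatter. Compound 3 `Cc1nc2c3ccccc3ccc2c2nc3c(ccc4ccccc43)c(-c3ccccc3)c12` differs from compound 2 in one place: hydrogen in place of methyl on an aromatic carbon. Among the measured compounds shown here, no measured step concerns this methyl; the single step available, a 2.0-fold higher number from compound 1 to compound 2 (0.29 log units; within the scatter), swaps a different group and is itself within the scatter. The expectation is therefore a step of a 1.2-fold lower number from compound 2 to compound 3 (0.09 log units; within the scatter) with no direction beyond the scatter. Compound 3 is expected to give about 55000 nM, within a range from 25000 nM to 120000 nM.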

Compound 3, half-maximal inhibitory concentration: > 80000 nM
Compound 3 ended at the assay's limit; the forecaster's own chance of this, stated with the estimate: 10%; at least 1.4-fold (0.16 log units) between middle value and limit.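

In this assay compound 3 gives > 80000 nM as a limit of the assay and not a number. Phenyl in place of pyridin-3-yl, with an at least 2.3-fold higher number from compound 1 to compound 3 (0.36 log units; beyond the scatter) as its step, is the first change at this position shown to clear the scatter, and it points to a weaker result. Hydrogen in place of methyl, with an at least 1.1-fold higher number from compound 2 to compound 3 (0.07 log units; that floor lies within the scatter) as its step, sets only a floor, so what the methyl does cannot be read.

Still open, from the compounds shown here alone, is the true number for compound 3. Also open, going by these compounds, is how an amine or a carboxylic acid on this aromatic ring would read, and whether any group here could give a lower number than pyridin-3-yl.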